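A few compounds are considered here, and "the series" means these few. Any claim that something is new, unique, unknown or untested is made for them only; others in the source may bear on it.

In a functional assay on RS4-11 cells (Homo sapiens) for inhibition, read by CCK-8 assay, with a stated time of 48 h (a lower number here means a stronger inhibitor, a higher number a weaker inhibitor), compound 1 `COc1ccc(S(=O)(=O)Oc2ccccc2/C=C(\C#N)C(=O)Nc2nnc(-c3cccs3)s2)cc1` gives 4750 nM and compound 2 `COc1ccc(Cc2nnc(NC(=O)/C(C#N)=C/c3ccccc3OS(=O)(=O)c3ccc(OC)cc3)s2)cc1` gives 840 nM, so compound 2 holds the lower of the two numbers. Compound 3 `COc1ccc(S(=O)(=O)Oc2ccccc2/C=C(\C#N)C(=O)Nc2nnc(Cc3cccc4ccccc34)s2)cc1` keeps the shared core and alters one group: naphthalen-1-yl in place of 4-methoxyphenyl on a saturated chain carbon bound to an aromatic carbon. For the measured compounds named here, only one measured step touches this part of the molecule, a 5.7-fold lower number from compound 1 to compound 2 (0.75 log units; beyond the scatter), where 4-methoxybenzyl replaced thiophen-2-yl. It shows that this part can shift the number, but not how a (naphthalen-1-yl)methyl group will behave. A small rise is therefore expected, an estimated 1.4-fold higher number from compound 2 to compound 3 (0.15 log units; within the scatter). For compound 3 the expected value is 1200 nM, with an estimated range of 350 nM to 4000 nM.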

Compound 3, half-maximal inhibitory concentration: 1360 nM
Estimate against measurement, compound 3: 1.1-fold (0.05 log units) below; low and high end bracket the measured number.
By their numbers in this assay, from the lowest: compounds 2 and 3 (each within the scatter of the next); then compound 1.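

In this assay the step of a 1.6-fold higher number from compound 2 to compound 3 (0.21 log units; within the scatter) shows that naphthalen-1-yl and 4-methoxyphenyl cannot be told apart on this saturated chain carbon, although the entering group has two aromatic rings and no oxygen. The step of a 3.5-fold lower number from compound 1 to compound 3 (0.54 log units; beyond the scatter) shows that the lower number seen against thiophen-2-yl is not tied to 4-methoxybenzyl alone, since (naphthalen-1-yl)methyl gives one too. Nothing available explains these numbers. Still open, as far as these compounds go, is how a cyclohexyl group or an amine would fare on this chain carbon, and whether a longer chain would keep the number.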